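Adding a cyclopropyl group to compound 2

This account rests on a few compounds, and the source may have more. Where it says the series, first, only, none or still open, it means among the compounds named here.

Of the compounds shown here, two have been measured so far in a physicochemical assay for solubility, at pH 1.1; on this read-out lower numbers stand for lower solubility and higher numbers for higher solubility. Compound 1 `CCCN(Cc1ccc(OCCN2C(=O)CCC2=O)c(C)c1)[C@H](CC(=O)O)c1ccc(Cl)cc1` gives 3000000 nM. Compound 2 `Cc1cc(CN(C)C(CC(=O)O)c2ccc(Cl)cc2)ccc1OCCn1c(=O)ccn(C)c1=O` gives 3000000 nM, which puts it level with compound 1, with nothing between them beyond the usual scatter of repeated measurements.

Compound 3 `Cc1cc(CN(CC2CC2)C(CC(=O)O)c2ccc(Cl)cc2)ccc1OCCn1c(=O)ccn(C)c1=O` has not yet been measured. It differs from compound 2 by a single change: cyclopropyl in place of hydrogen on a saturated chain carbon bound to an amine nitrogen. In words, cyclopropyl stands in place of hydrogen on a saturated chain carbon bound to an amine nitrogen, so the same difference can also be read as methyl to cyclopropylmethyl.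

Among the measured compounds shown here, no measured pair of compounds shows what a change of this kind does, so any forecast is uncertain. Starting from compound 2 at 3000000 nM, no step beyond the scatter is expected in this assay. In numbers, the expected change is no change at the digits printed from compound 2 to compound 3 (within the scatter). For compound 3 the estimated value is 3000000 nM, with an expected range of 1500000 nM to 4000000 nM.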

Compound 3, solubility: 3000000 nM
Compound 3: the middle estimate sits on the measured number at the digits printed; measured number inside the range.
By their numbers in this assay, from the lowest: compounds 1, 2 and 3 (each within the scatter of the next).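

In this assay, among the compounds shown here, this is the first step that can be read between two compounds differing in one place: cyclopropyl in place of hydrogen on a saturated chain carbon bound to an amine nitrogen gives no change at the digits printed from compound 2 to compound 3 (within the scatter). Read one bond further out, the same difference is methyl to cyclopropylmethyl, so at this position a change that brings in 3 heavy atoms and a three-membered carbon ring leaves no step beyond the scatter on this read-out. Nothing in the available data accounts for this outcome.

This single step says nothing about how far the position can be changed before the read-out moves, so a longer chain such as n-butyl, a phenyl ring or a chain ending in a hydroxyl group in place of cyclopropyl remains an open case. It also leaves open whether the same exchange of hydrogen for cyclopropyl would give a similar result on a different core, or at a pH other than the one tested here.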